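Working notes: cycloheptyl in place of cyclohexyl on the amide

The compounds below may be only part of what the source reports. "The series", "measured", "known", "first", "only" and "open" are said of these compounds alone.

- compound 1 `CC(C)=CCC/C(C)=C/CC/C(C)=C/CSC[C@H](NC(=O)CCCCCN1CCCC1)C(=O)NC1CCCCC1` gives 12700 nM as its value
- compound 2 `CC(C)=CCC/C(C)=C/CC/C(C)=C/CSC[C@H](NC(=O)CCCCCN1CCN(C)CC1)C(=O)N1CCCCC1` gives 8800 nM as its value

In a functional assay on BXPC-3 cells (Homo sapiens) for cytotoxicity, read by fluorescence, with a stated time of 48 h (a higher number here means that more compound is needed for the effect, a lower number that less compound is needed), compound 1 stands at 12700 nM and lies within the scatter of compound 2, so the two numbers give no order. These two compounds differ in more than one place, so they offer no single-change step to reason from.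

Compound 3 `CC(C)=CCC/C(C)=C/CC/C(C)=C/CSC[C@H](NC(=O)CCCCCN1CCCC1)C(=O)NC1CCCCCC1` is the next case. Its difference from compound 1 is cycloheptyl in place of cyclohexyl on an amide-type nitrogen and amounts to cycloheptyl in place of cyclohexyl on an amide-type nitrogen. Among the compounds with values here, with no measured step for this change, no shift beyond the scatter is expected in this assay in either direction.

The expected step is a 1.3-fold lower number from compound 1 to compound 3 (0.10 log units; within the scatter) on this estimate. Compound 3 is estimated at 10000 nM with an expected range from 5000 nM to 20000 nM in this assay.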

Compound 3, half-maximal effective concentration: 5800 nM
The estimate for compound 3 lay 1.7-fold (0.24 log units) above the measured number, and the stated range covers the measured number.
By their numbers in this assay, from the lowest: compounds 3, 2 and 1 (each within the scatter of the next, the first and the last beyond it).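

Within the data shown here, this is the first single-change step. On an amide-type nitrogen whose other neighbour is the carbonyl carbon, cycloheptyl in place of cyclohexyl gives a 2.2-fold lower number from compound 1 to compound 3 (0.34 log units; beyond the scatter) in this assay, a modest step, so one added ring carbon at this position is enough to move the number beyond the scatter, at least in this pair. No measurement in hand bears on why the number moves.

As far as these compounds go, the step rests on a single pair, so the trend in ring size remains undefined: whether the number keeps falling with cyclooctyl, or whether it holds with an open chain such as n-heptyl on the same nitrogen, stays open. Also open, from the compounds shown here alone, is whether a benzyl group, which keeps a ring but sets it one carbon further out, would fit the same trend.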